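Nitrofuran amides: cytotoxicity on MRC5 cells, compound 3 outlook

This account rests on a few compounds, and the source may have more. Where it says the series, first, only, none or still open, it means among the compounds named here.

Measured so far:
compound 1 `COc1ccc(Cn2cc(CNC(=O)c3ccc([N+](=O)[O-])o3)nn2)cc1O`: 189000 nM
compound 2 `COc1ccc(Cn2cc(CNC(=O)c3ccc([N+](=O)[O-])o3)nn2)cc1F`: 324000 nM

In an ADME assay on MRC5 cells (Homo sapiens) for cytotoxicity (on this read-out lower numbers stand for stronger inhibition and higher numbers for weaker inhibition), compound 1 gives 189000 nM, the lowest of the two numbers; compound 2 follows with a 1.7-fold higher number from compound 1 to compound 2 (0.23 log units; within the scatter), so the two stand together. Compound 3 `O=C(NCc1cn(Cc2ccc(F)c(Cl)c2)nn1)c1ccc([N+](=O)[O-])o1` is not yet measured. It differs from compound 1 by 3-chloro-4-fluorophenyl in place of 3-hydroxy-4-methoxyphenyl on a saturated chain carbon bound to an aromatic nitrogen. Among the compounds with values here, the only step at this place is the one from compound 1 to compound 2, which stayed within the scatter. For compound 3 the expected step is a 1.3-fold higher number from compound 1 to compound 3 (0.12 log units; within the scatter). Compound 3 is estimated at 250000 nM, range 100000 nM to 600000 nM.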

Compound 3, half-maximal inhibitory concentration: 254000 nM
Compound 3: the middle estimate sits 1.0-fold (0.01 log units) below what was measured; measured number inside the range.
By their numbers in this assay, from the lowest: compounds 1, 3 and 2 (each within the scatter of the next).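

Swapping the whole aryl group, not just one substituent, still moves little in this assay: 3-chloro-4-fluorophenyl in place of 3-hydroxy-4-methoxyphenyl gives a 1.3-fold higher number from compound 1 to compound 3 (0.13 log units; within the scatter) and in place of 3-fluoro-4-methoxyphenyl gives a 1.3-fold lower number from compound 2 to compound 3 (0.11 log units; within the scatter) on this saturated chain carbon bound to an aromatic nitrogen. Losing both the hydrogen-bond donor and the acceptors of compound 1 therefore leaves the number within the scatter. No evidence on the reason is available here.

Open, as far as these compounds go, is whether an amine or a carboxylic acid on the aromatic ring would separate from these three compounds. From the compounds shown here alone, a longer chain at this place also remains open.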